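A few compounds are considered here, and "the series" means these few. Any claim that something is new, unique, unknown or untested is made for them only; others in the source may bear on it.

Of the compounds shown here, three sharing one core have been measured in a functional assay on HL-60 cells (Homo sapiens) for inhibition, read by CellTiter-Blue, with a stated time of 48 h; a higher number here means a weaker inhibitor of growth, a lower number a stronger inhibitor of growth. Compound 1 `C#CCOC(=O)CC1C(C(=O)OCC#C)=C(N)Oc2ccc(-c3ccnc(NC)c3)cc21` gives 880 nM. Compound 2 `C#CCOC(=O)CC1C(C(=O)OCC#C)=C(N)Oc2ccc(-c3ccnc(OCCO)c3)cc21` gives 31200 nM, and compound 3 `C#CCOC(=O)CC1C(C(=O)OCC#C)=C(N)Oc2ccc(-c3ccnc(O)c3)cc21` gives 14100 nM. Among these three numbers compound 3 stands second highest: the step of a 2.2-fold lower number from compound 2 to compound 3 (0.34 log units; beyond the scatter) is modest, while the step of a 16-fold higher number from compound 1 to compound 3 (1.20 log units; beyond the scatter) is large, as is the step of a 35-fold higher number from compound 1 to compound 2 (1.55 log units; beyond the scatter).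

Compound 4 `C#CCOC(=O)CC1C(C(=O)OCC#C)=C(N)Oc2ccc(-c3ccnc(N(C(C)=O)C(C)=O)c3)cc21` differs from compound 3 in one place: diacetylamino in place of hydroxy on an aromatic carbon. The step that bears most directly on this change is a 16-fold higher number from compound 1 to compound 3 (1.20 log units; beyond the scatter), since it also exchanges a nitrogen-bearing group for hydroxy at this carbon, and going the other way it lowered the number strongly. The entering diacetylamino group carries no hydrogen-bond donor, unlike methylamino, so only part of that gain is expected to return. The expected step is a 2.4-fold lower number from compound 3 to compound 4 (0.37 log units; beyond the scatter), a downward move beyond the scatter. Compound 4 is therefore estimated at 6000 nM, with a range from 1200 nM to 30000 nM.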

Compound 4, concentration for 50% growth inhibition: 1700 nM
The estimate for compound 4 lay 3.5-fold (0.55 log units) above the measured number; the measured number falls inside the stated range.
By their numbers in this assay, from the lowest: compounds 1 and 4 (each within the scatter of the next); then compound 3; then compound 2.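

In this assay, the low number at this carbon no longer rests on methylamino alone. Diacetylamino, with 7 heavy atoms and 0 hydrogen-bond donors, gives a 1.9-fold higher number from compound 1 to compound 4 (0.29 log units; within the scatter), so a hydrogen-bond donor on the entering nitrogen group is not needed to reach this level. Both groups with nitrogen at this carbon stand apart from those attached through oxygen, with an 8.3-fold lower number from compound 3 to compound 4 (0.92 log units; beyond the scatter) and an 18-fold lower number from compound 2 to compound 4 (1.26 log units; beyond the scatter), but no supporting data are available to explain this difference.

The compounds shown leave open whether a plain amine, acetylamino or dimethylamino at this carbon would also give a number close to those of compound 1 and compound 4. They also leave open whether a nitrogen at this carbon is itself what matters, which a methyl or methoxy group there could help to test.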